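Swapping the Acyl Group on the Arm of Compound 3

The compounds below may be only part of what the source reports. "The series", "measured", "known", "first", "only" and "open" are said of these compounds alone.

Three analogues share one core and differ in the acyl group and in a ring hydroxy. Compound 1 `Nc1ncnc2c1ncn2[C@@H]1CO[C@H](COS(=O)(=O)NC(=O)[C@@H]2CCCN2)[C@@H](O)C1` gives 2800 nM in a functional assay on PBMC cells (Homo sapiens) for inhibition; on this read-out higher numbers stand for weaker inhibition and lower numbers for stronger inhibition. Compound 2 `CC(C)C[C@H](N)C(=O)NS(=O)(=O)OC[C@H]1OC[C@@H](n2cnc3c(N)ncnc32)[C@H](O)[C@@H]1O` gives 1000 nM in this assay. Compound 3 `Nc1ncnc2c1ncn2[C@@H]1CO[C@H](COS(=O)(=O)NC(=O)[C@@H]2CCCN2)[C@@H](O)[C@H]1O` gives 750 nM in this assay, the lowest of the three numbers. The step of a 3.7-fold lower number from compound 1 to compound 3 (0.57 log units; beyond the scatter) lies beyond the scatter, whereas the step of a 1.3-fold lower number from compound 2 to compound 3 (0.12 log units; within the scatter) lies within it. Compound 4 `C[C@H](N)C(=O)NS(=O)(=O)OC[C@H]1OC[C@@H](n2cnc3c(N)ncnc32)[C@H](O)[C@@H]1O` carries 1-aminoethyl in place of pyrrolidin-2-yl on a carbonyl carbon. This change is comparable to the step of a 1.3-fold lower number from compound 2 to compound 3 (0.12 log units; within the scatter), which likewise swaps the group on the carbonyl carbon and stayed within the scatter. No step beyond the scatter is therefore expected in this assay. Compound 4 is estimated at 1000 nM, with a range from 400 nM to 2500 nM. The expected step is a 1.3-fold higher number from compound 3 to compound 4 (0.12 log units; within the scatter).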

Compound 4, half-maximal inhibitory concentration: 300 nM
The estimate for compound 4 lay 3.3-fold (0.52 log units) above the measured number; measured number outside the range, below it.
By their numbers in this assay, from the lowest: compound 4; then compounds 3 and 2 (each within the scatter of the next); then compound 1.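

In this assay the group on the carbonyl carbon proved able to move the number beyond the scatter, which the earlier swap there had not shown: 1-aminoethyl in place of pyrrolidin-2-yl gives a 2.5-fold lower number from compound 3 to compound 4 (0.40 log units; beyond the scatter) on the same core. Hydrogen in place of isopropyl on the saturated chain carbon gives a 3.3-fold lower number from compound 2 to compound 4 (0.52 log units; beyond the scatter) as well, so 1-aminoethyl stands apart from both 1-amino-3-methylbutyl and pyrrolidin-2-yl. Nothing available explains either step.

As far as these compounds go, whether aminomethyl on the carbonyl carbon would give a still lower number stays open, as does the effect of a 1-amino-2-hydroxyethyl group there.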